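Chain extension on the core of compound 1

The source may report more compounds than this note shows. Statements on the series, on what has been measured and on what is new or still open speak of the compounds shown alone.

Measured values in a functional assay on A549 cells (Homo sapiens) for inhibition, read by MTT assay, with a stated time of 72 h (a lower number here means a stronger inhibitor, a higher number a weaker inhibitor), all of them limits:
- compound 1 `Nc1nc2cc(-c3nn(CCCC(=O)NO)c4ncnc(N)c34)ccc2o1`: > 100000 nM
- compound 2 `Nc1ncnc2c1c(-c1cnc3[nH]ccc3c1)nn2CCCCC(=O)NO`: > 150000 nM
- compound 3 `Nc1ncnc2c1c(-c1cnc3[nH]ccc3c1)nn2CCCCCC(=O)NO`: > 150000 nM

For the measured compounds named here, no compound in this assay has yet given a number. Compound 1 sits at the limit of > 100000 nM in this assay, at which 1 of the 3 values shown sits. Compounds 2 and 3 sit at the limit of > 150000 nM in this assay, at which 2 of the 3 values shown sit.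

The next compound is compound 4 `Nc1nc2cc(-c3nn(CCCCCC(=O)NO)c4ncnc(N)c34)ccc2o1`. The change from compound 1 is 2-(hydroxycarbamoyl)ethyl in place of hydroxycarbamoyl on a saturated chain carbon, three bonds along the chain from an aromatic nitrogen.

The only measured chain extension is a step that the two limits leave unreadable from compound 2 to compound 3, on a different core, so it gives no size to carry over. The 5-(hydroxycarbamoyl)pentyl chain of compound 4 also stands on compound 3, which remains at a limit, > 150000 nM.

With no readable step, the direction is a loose expectation only, and another limit is quite likely. The expected step is an at least 2.0-fold lower number from compound 1 to compound 4 (0.30 log units; that floor lies within the scatter), a modest move toward stronger inhibition. Compound 4 is estimated at 50000 nM, with an expected range of 3000 nM to 150000 nM.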

Compound 4, half-maximal inhibitory concentration: > 100000 nM
Compound 4 gave a limit, no number (the forecaster's own chance of this, stated with the estimate: 55%); at least 2.0-fold (0.30 log units) between middle value and limit.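

In this assay compound 4 gives > 100000 nM, a limit and not a number. Compound 1 also gives a limit, > 100000 nM, so the step to compound 4 cannot be read. The compounds shown leave open whether any hydroxycarbamoyl chain on the shared core gives a measurable value.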